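Akt binding series: amide substituent swap on the shared core

A few compounds are considered here, and "the series" means these few. Any claim that something is new, unique, unknown or untested is made for them only; others in the source may bear on it.

Measured compounds:
compound 1 `O=C(CSc1nnc(COc2ccc3c(c2)CCCC3)o1)Nc1nc2ccc(F)cc2s1` with 165000 nM in an assay on C6 cells for inhibition of RAC-alpha serine/threonine-protein kinase (Rattus norvegicus), read by ELISA, with a stated time of 24 h; a lower number here means a stronger inhibitor, a higher number a weaker inhibitor
compound 2 `COc1ccc2nc(NC(=O)CSc3nnc(COc4ccc5c(c4)CCCC5)o3)sc2c1` with 2600 nM in this assay

Compound 2 holds the lowest of the two numbers in this assay. Among the measured compounds shown here, the only measured step is a 63-fold lower number from compound 1 to compound 2 (1.80 log units; beyond the scatter), which came from methoxy in place of fluoro on an aromatic carbon, so the group on the amide-type nitrogen clearly matters for this assay.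

Compound 3 `O=C(CSc1nnc(COc2ccc3c(c2)CCCC3)o1)Nc1ncc([N+](=O)[O-])s1` is not yet measured. It differs from compound 2 by 5-nitro-1,3-thiazol-2-yl in place of 6-methoxy-1,3-benzothiazol-2-yl on an amide-type nitrogen. For the measured compounds named here, no measured step covers this change; the one step known concerns only a substituent on the same ring system, not its replacement. The sensitivity of this position argues for a sizeable step in this assay, but its direction cannot be read from the data, so the expectation sits above compound 2 with a wide range.

For compound 3 the expected value in this assay is 20000 nM, between 2000 nM and 200000 nM, meaning an expected step of a 7.7-fold higher number from compound 2 to compound 3 (0.89 log units; beyond the scatter).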

Compound 3, half-maximal inhibitory concentration: 44500 nM
The estimate for compound 3 lay 2.2-fold (0.35 log units) below the measured number, within the range that was stated.
By their numbers in this assay, from the lowest: compound 2; then compound 3; then compound 1.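

In this assay, 5-nitro-1,3-thiazol-2-yl on the amide-type nitrogen gives a 17-fold higher number from compound 2 to compound 3 (1.23 log units; beyond the scatter), so this smaller group does not keep the standing of 6-methoxy-1,3-benzothiazol-2-yl. Against 6-fluoro-1,3-benzothiazol-2-yl, the same replacement gives a 3.7-fold lower number from compound 1 to compound 3 (0.57 log units; beyond the scatter), so the outcome of losing the six-membered ring depends on which benzothiazolyl group is the reference, and 5-nitro-1,3-thiazol-2-yl places compound 3 between compound 2 and compound 1. No measurement available here explains this order.

Going by these compounds, the nitro group and the ring change are not separated in these compounds, so their individual contributions remain open. A 1,3-thiazol-2-yl carrying methoxy in place of nitro, or a 1,3-benzothiazol-2-yl carrying an amine in place of methoxy, would test whether the ring or its substituent governs the number.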